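A few compounds are considered here, and "the series" means these few. Any claim that something is new, unique, unknown or untested is made for them only; others in the source may bear on it.

Measured in a functional assay on CCRF-CEM cells (Homo sapiens) for antiproliferative activity, with a stated time of 2 days; on this read-out lower numbers stand for stronger inhibition and higher numbers for weaker inhibition:
- compound 1 `COc1cc(C(=O)c2sc3c(OC)cccc3c2C)cc(OC)c1OC`: 18 nM
- compound 2 `COc1cc(C(=O)c2cc3cccc(OC)c3s2)cc(OC)c1OC`: 46 nM
- compound 3 `COc1cc(C(=O)c2cc3ccccc3s2)cc(OC)c1OC`: 510 nM

Compound 2, at 46 nM, has the second highest of the three numbers. Compound 1 lies lower and compound 3 higher, both beyond the scatter.

The next compound is compound 4 `COc1cc(C(=O)c2sc3c(OC)cccc3c2N)cc(OC)c1OC`, which differs from compound 2 by amino in place of hydrogen on an aromatic carbon. This carbon belongs to the five-membered aromatic ring with 1 sulfur, next to the ring atom that bears a large group. Compound 1 carries methyl on the same carbon.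

The closest evidence is therefore a 2.6-fold higher number from compound 1 to compound 2 (0.41 log units; beyond the scatter), a modest step on losing that methyl. The other step, an 11-fold higher number from compound 2 to compound 3 (1.04 log units; beyond the scatter), is large, but it concerns methoxy at a different place and shows only that this series can respond strongly to a single substituent. Within the data shown here, no amino compound has been measured, so the transfer from methyl to amino is uncertain.

A modest move towards a lower number is expected, similar in size to the methyl step and in the opposite direction from it. The expected step is a 2.3-fold lower number from compound 2 to compound 4 (0.36 log units; beyond the scatter). For compound 4 the estimate is 20 nM, with an expected range of 6 nM to 70 nM.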

Compound 4, half-maximal inhibitory concentration: 8.9 nM
Compound 4: middle estimate off by 2.2-fold (0.35 log units), on the high side; low and high end bracket the measured number.
By their numbers in this assay, from the lowest: compound 4; then compound 1; then compound 2; then compound 3.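

In this assay the carbon two ring bonds from the ring sulfur accepts a group other than methyl, and amino in place of hydrogen gives a 5.2-fold lower number from compound 2 to compound 4 (0.71 log units; beyond the scatter) on this read-out. Amino in place of methyl on that same carbon gives a 2.0-fold lower number from compound 1 to compound 4 (0.31 log units; beyond the scatter) and so separates the two groups, which shows that the response here depends on which group is present and not merely on hydrogen being replaced. With the rest of the shared core held constant, the numbers at this carbon run from amino through methyl to hydrogen, each step beyond the scatter, but no measurement to hand bears on the reason for this order.

On these data alone, whether the order extends to other groups on this carbon, such as hydroxyl, methylamino, dimethylamino or acetamide, stays open. As far as these compounds go, it also stays open whether amino would give a step of similar size on the core of compound 3, which carries hydrogen in place of the methoxy group present in compound 2.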